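Selenium for Sulfur: A Step Seen Once, Expected Again

The compounds below may be only part of what the source reports. "The series", "measured", "known", "first", "only" and "open" are said of these compounds alone.

Compound 2 `CS/C(=N\C(=O)c1cccs1)NC(=O)c1cccs1` and compound 1 `C[Se]/C(=N\C(=O)c1cccs1)NC(=O)c1cccs1` differ by a single change: a group of 2 heavy atoms (1 carbon, 1 selenium; no ring) in place of a group of 2 heavy atoms (1 carbon, 1 sulfur; no ring), on a carbon with a double bond to nitrogen. In a functional assay on MCF7 cells (Homo sapiens) for cytotoxicity, read by MTT assay, with a stated time of 72 h (a higher number here means a weaker inhibitor of growth, a lower number a stronger inhibitor of growth), compound 2 gives 89000 nM, while compound 1 gives 5640 nM; the step between them is a 16-fold lower number from compound 2 to compound 1 (1.20 log units; beyond the scatter). Compound 3 `CS/C(=N\C(=O)c1cc(-c2ccccc2)nc2ccccc12)NC(=O)c1cc(-c2ccccc2)nc2ccccc12` rests on another core; the difference between the cores of compound 2 and compound 3 is not broken down here. In this assay compound 3 gives 87700 nM, within the scatter of compound 2. Compound 4 `C[Se]/C(=N\C(=O)c1cc(-c2ccccc2)nc2ccccc12)NC(=O)c1cc(-c2ccccc2)nc2ccccc12` differs from compound 3 by a group of 2 heavy atoms (1 carbon, 1 selenium; no ring) in place of a group of 2 heavy atoms (1 carbon, 1 sulfur; no ring), on a carbon with a double bond to nitrogen, the same change as before, at the same kind of place. An expected step of a 16-fold lower number from compound 3 to compound 4 (1.20 log units; beyond the scatter) is estimated because the same change earlier gave a 16-fold lower number from compound 2 to compound 1 (1.20 log units; beyond the scatter). Compound 4 is therefore expected near 5500 nM, with a range from 1500 nM to 20000 nM.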

Compound 4, concentration for total growth inhibition: 7520 nM
Estimate against measurement, compound 4: 1.4-fold (0.14 log units) below; low and high end bracket the measured number.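

In this assay, methylsulfanyl giving way to its selenium counterpart, on a carbon with a double bond to nitrogen, brings a 12-fold lower number from compound 3 to compound 4 (1.07 log units; beyond the scatter), and this step agrees with the one seen on the core of compound 2: the same change on two cores in this assay, a 16-fold lower number (1.20 log units; beyond the scatter) from compound 2 to compound 1 and a 12-fold lower number (1.07 log units; beyond the scatter) from compound 3 to compound 4, 1.4-fold (0.13 log units) apart, within the scatter of two such steps. The change therefore carried over between these two cores, in this one assay, with a size that held as well as the scatter can tell. Two pairs do not show that it would carry to a further core or to another assay, and they do not say why the number falls.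

The compounds shown leave open whether the step survives when a longer chain, such as ethyl or benzyl, replaces the methyl on selenium or sulfur. They also leave open what happens when the core carries an amine or a carboxylic acid.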